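This account rests on a few compounds, and the source may have more. Where it says the series, first, only, none or still open, it means among the compounds named here.

Series notes on a functional assay on RS4-11 cells (Homo sapiens) for inhibition, read by CCK-8 assay, with a stated time of 48 h; a lower number here means a stronger inhibitor, a higher number a weaker inhibitor.

Compound 3 `O=S(=O)(c1sccc1-c1ccccc1Oc1ccc(O)c(O)c1)N1CCN(C(=S)Nc2cc(C(F)(F)F)cc(C(F)(F)F)c2)CC1` gives 7300 nM in this assay. Compound 1 `COc1ccc(Oc2ccccc2-c2ccsc2S(=O)(=O)N2CCN(C(=S)Nc3cc(C(F)(F)F)cc(C(F)(F)F)c3)CC2)cc1OC` shows only a limit of this assay, > 50000 nM. The change between them, (3,4-dimethoxyphenyl in place of 3,4-dihydroxyphenyl on an oxygen on an aromatic ring), produces an at least 6.8-fold higher number from compound 3 to compound 1 (0.83 log units; beyond the scatter); the size of that step is set by the limit of > 50000 nM in this assay, at which 1 of the 3 values shown sits, so only its lower bound is known.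

Compound 2 `CC(C)c1ccc(Oc2ccc(O)c(O)c2)c(-c2ccsc2S(=O)(=O)NCCNC(=O)Nc2cc(C(F)(F)F)cc(C(F)(F)F)c2)c1` gives 6800 nM in this assay, which sits within the scatter of compound 3. How the core of compound 2 differs from the core of compound 3 is not broken down here.

Compound 4 `COc1ccc(Oc2ccc(C(C)C)cc2-c2ccsc2S(=O)(=O)NCCNC(=O)Nc2cc(C(F)(F)F)cc(C(F)(F)F)c2)cc1OC` has not been measured. Among the compounds with values here, it carries, relative to compound 2, (3,4-dimethoxyphenyl in place of 3,4-dihydroxyphenyl on an oxygen on an aromatic ring), the same change as the one from compound 3 to compound 1. The step from compound 2 to compound 4 in this assay is expected to be a 6.6-fold higher number from compound 2 to compound 4 (0.82 log units; beyond the scatter), resting on the step from compound 3 to compound 1 an at least 6.8-fold higher number from compound 3 to compound 1 (0.83 log units; beyond the scatter). The estimate for compound 4 is 45000 nM, expected to lie between 15000 nM and 150000 nM.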

Compound 4, half-maximal inhibitory concentration: 11700 nM
Estimate against measurement, compound 4: 3.8-fold (0.59 log units) above, outside the stated range (below it).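

In this assay, on the core of compound 2, 3,4-dimethoxyphenyl in place of 3,4-dihydroxyphenyl gives a 1.7-fold higher number from compound 2 to compound 4 (0.24 log units; within the scatter), and this step does not match the one on the core of compound 3: the same change on two cores in this assay, an at least 6.8-fold higher number (0.83 log units; beyond the scatter) from compound 3 to compound 1 and a 1.7-fold higher number (0.24 log units; within the scatter) from compound 2 to compound 4, at least 3.9-fold (0.59 log units) apart, beyond the scatter of two such steps. Compound 1 gives only a limit of the assay, > 50000 nM, so the step on that core has a lower bound and no known size. With one pair on each of two cores, the change is shown not to carry over at a fixed size between these cores, but neither the part of the core responsible nor any behaviour on other cores is shown.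

The compounds shown leave open which of the differences between the two cores goes with the different step, as no pair here separates them. Also open, as far as these compounds go, is how either core responds when the 3,4-dihydroxyphenyl group gives way to a phenyl ring carrying a single hydroxyl or a carboxylic acid.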